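Fluoro for hydrogen on the aryl ring of compound 1

The compounds below may be only part of what the source reports. "The series", "measured", "known", "first", "only" and "open" are said of these compounds alone.

Measured so far:
compound 1 `Cc1nnc(SCC(=O)N/N=c2/scc(-c3ccccc3)n2-c2ccccc2)s1`, 72.4%
compound 2 `O=C(CSc1nnnn1-c1ccccc1)N/N=c1/scc(-c2ccc(Br)cc2)n1-c1ccccc1`, 61.8%

In a functional assay on C6 cells (Rattus norvegicus) for cytotoxicity, read by MTT assay, with a stated time of 24 h, tested at 6 ug/mL (on this read-out higher numbers stand for a weaker effect at the one concentration tested and lower numbers for a stronger effect), compound 1 gives the higher of the two numbers; compound 2 sits lower, and the gap between the two lies beyond the scatter. Within the data shown here, no pair here differs in only one place, so no single step can be read off.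

Compound 3 `Cc1nnc(SCC(=O)N/N=c2/scc(-c3ccc(F)cc3)n2-c2ccccc2)s1` differs from compound 1 in one place: fluoro in place of hydrogen on an aromatic carbon. Among the measured compounds shown here, with no comparable step among the measured compounds, the step from compound 1 to compound 3 is expected to be small or none beyond the scatter, a number 2.4 percentage points lower from compound 1 to compound 3 (within the scatter). In this assay compound 3 is estimated at 70%, within 56% to 84%.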

Compound 3, a percentage reported as activity, at one concentration (the size of the read-out at that concentration, not a potency): 74.3%
The estimate for compound 3 lay 4.3 percentage points below the measured number; the measured number falls inside the stated range.
By their numbers in this assay, from the lowest: compound 2; then compounds 1 and 3 (each within the scatter of the next).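

In this assay, among these compounds, phenyl to 4-fluorophenyl gives a number 1.9 percentage points higher from compound 1 to compound 3 (within the scatter), the first step that can be read at a single place. On this aromatic carbon, para to a large group, fluoro and hydrogen cannot be told apart on this read-out. No measurement at hand accounts for this result.

On these data alone, it remains open whether an amine or a carboxylic acid on this same carbon would separate from hydrogen. Compound 2 differs from compound 1 in more than one place, so the part played by its bromo stays unresolved.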